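Swapping the Aryl Tail: Methylpyridazine Gives Way to Cyanopyridine

The compounds below may be only part of what the source reports. "The series", "measured", "known", "first", "only" and "open" are said of these compounds alone.

Measured compounds:
compound 1 `Cc1ccc(-c2ccc(Cl)c(C(=O)NCC3(O)CCCCCC3)c2)nn1`: 18 nM
compound 2 `O=C(NCC1(O)CCCC(F)(F)C1)c1cc(-c2ncc(F)cn2)ccc1Cl`: 51 nM
compound 3 `O=C(NCC1(O)CCCC(F)(F)CC1)c1cc(-c2ncc(F)cn2)ccc1Cl`: 46 nM

All three compounds share an amide core carrying a chloro group and a ring-bearing alcohol side chain, and all were tested in a functional assay on HEK293 cells for antagonist activity at P2X purinoceptor 7 (Homo sapiens); on this read-out lower numbers stand for stronger inhibition and higher numbers for weaker inhibition. Compound 1 gives 18 nM, the lowest number of the three. Compound 3 gives 46 nM and compound 2 gives 51 nM; both gaps to compound 1 lie beyond the scatter, so compound 1 is the strongest inhibitor of the set.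

Compound 4 `N#Cc1ccc(-c2ccc(Cl)c(C(=O)NCC3(O)CCCCCC3)c2)nc1` keeps the core and side chain of compound 1 and changes only the aromatic tail: 5-cyanopyridin-2-yl in place of 6-methylpyridazin-3-yl on an aromatic carbon. A methyl-bearing ring with two nitrogens is traded for a nitrile-bearing ring with one nitrogen. Within the data shown here, the tail is the one part of compound 1 that the other measured compounds also vary, and their numbers stay within a narrow band, so no large shift is expected. The step from compound 1 to compound 4 is estimated to be a 1.2-fold lower number from compound 1 to compound 4 (0.08 log units; within the scatter), not beyond the scatter. Compound 4 is therefore expected to give about 15 nM, most likely between 5 nM and 50 nM.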

Compound 4, half-maximal inhibitory concentration: 134 nM
For compound 4 the middle estimate is 8.9-fold (0.95 log units) below the measured one, outside the stated range (above it).
By their numbers in this assay, from the lowest: compound 1; then compounds 3 and 2 (each within the scatter of the next); then compound 4.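

In this assay, among these compounds, this is the first pair in which the aromatic tail alone changes, since the earlier compounds differ from compound 1 in both tail and side chain, and 5-cyanopyridin-2-yl in place of 6-methylpyridazin-3-yl brings a 7.4-fold higher number from compound 1 to compound 4 (0.87 log units; beyond the scatter) on an otherwise unchanged molecule. The position on the carbon para to the chloro group is therefore sensitive to which ring stands there, even though both tails are six-membered aromatic rings with the same count of hydrogen-bond acceptors. Nothing available here explains why inhibition weakens.

On these data alone, it remains open whether the nitrile, the lost ring nitrogen or the missing methyl matters most, and how an amine or a methoxy group on this ring would compare. As far as these compounds go, it is also open whether the same tail change would weaken inhibition to a similar degree on the fluorinated side chains of compound 2 and compound 3.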